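From 4-fluorobenzyl to allyl on the shared core

The source may report more compounds than this note shows. Statements on the series, on what has been measured and on what is new or still open speak of the compounds shown alone.

Compound 1 `C=CCOc1ccc2c(NCCN(C)C)ccnc2c1` gives 860 nM
Compound 2 `CN(C)CCCNc1ccnc2cc(OCc3ccc(F)cc3)ccc12` gives 740 nM

Both were tested in a functional assay on HCT-116 cells (Homo sapiens) for cytotoxicity, read by MTT assay, with a stated time of 48 h (a higher number here means a weaker inhibitor, a lower number a stronger inhibitor), and their values lie within the scatter of each other, so compound 2 stands level with compound 1 on these numbers. Compound 3 `C=CCOc1ccc2c(NCCCN(C)C)ccnc2c1` has vinyl in place of 4-fluorophenyl on a saturated chain carbon bound to an oxygen on an aromatic ring. Among the compounds with values here, no measured pair isolates this change. Compound 1 also carries allyl and gives 860 nM in this assay so no step beyond the scatter is expected, though a small one towards a higher number remains possible. The estimated change is a 1.2-fold higher number from compound 2 to compound 3 (0.09 log units; within the scatter) and it remains only an expectation. Compound 3 is expected at 900 nM (estimated range 350 nM to 2200 nM).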

Compound 3, half-maximal inhibitory concentration: 2100 nM
The estimate for compound 3 lay 2.3-fold (0.37 log units) below the measured number; measured number inside the range.
By their numbers in this assay, from the lowest: compounds 2 and 1 (each within the scatter of the next); then compound 3.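

In this assay the step of a 2.8-fold higher number from compound 2 to compound 3 (0.45 log units; beyond the scatter) shows that 4-fluorobenzyl to allyl, read on its own, costs activity at this oxygen, which compound 1 could not show because it differs from compound 2 in two places. With allyl held, the step of a 2.4-fold higher number from compound 1 to compound 3 (0.39 log units; beyond the scatter) shows that (dimethylamino)methyl in place of dimethylamino also shifts the number beyond the scatter. Nothing measured here accounts for either step.

Still open, as far as these compounds go, is whether the loss follows the aromatic ring or its fluorine, which an unsubstituted benzyl would separate. From the compounds shown here alone, how a pyrrolidine in place of dimethylamino would read also remains unknown.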